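Adding a Nitro Group: Expected Effect on Cell Toxicity

The source may report more compounds than this note shows. Statements on the series, on what has been measured and on what is new or still open speak of the compounds shown alone.

Measured so far in an ADME assay on J744 cells (Mus musculus) for cytotoxicity, read by MTT assay, with a stated time of 48 h; on this read-out lower numbers stand for stronger inhibition and higher numbers for weaker inhibition:
Compound 1 `O=C(O)c1ccc(/C=N/NC(=O)c2c(-c3ccccc3)no[n+]2[O-])cc1` reaches only the assay limit, > 300000 nM.
Compound 2 `Cc1c(C(=O)N/N=C/c2cccs2)no[n+]1[O-]` reaches only the assay limit, > 400000 nM.
Compound 3 `Cc1nc2ccccn2c1C(=O)N/N=C/c1no[n+]([O-])c1C` reaches only the assay limit, > 400000 nM.

None of the three gives a number; every value is a limit. Compound 2 stands at the limit (the limit of > 400000 nM in this assay, at which 2 of the 3 values shown sit). Compound 1 stands at the other limit (the limit of > 300000 nM in this assay, at which 1 of the 3 values shown sits). Within the data shown here, no step between two measured compounds is available.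

Compound 4 `Cc1c(C(=O)N/N=C/c2ccc([N+](=O)[O-])s2)no[n+]1[O-]` differs from compound 2 by one change: nitro in place of hydrogen on an aromatic carbon. Among the measured compounds shown here, with no measured step to lean on, the step expected in this assay is none beyond the scatter, a number no higher from compound 2 to compound 4 (the limit leaves the size open). Compound 4 is expected at 400000 nM, most likely reported again only as a limit, within the range 100000 nM to 1000000 nM.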

Compound 4, half-maximal inhibitory concentration: 68000 nM
Compound 4: the middle estimate sits 5.9-fold (0.77 log units) above what was measured; the whole stated range lies above it.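

In this assay, nitro in place of hydrogen on an aromatic carbon, next to the ring sulfur, gives an at least 5.8-fold lower number from compound 2 to compound 4 (0.76 log units; beyond the scatter). Compound 4 is the only compound shown with a real number rather than a limit, so this one change at this position brings cell toxicity into the measurable range. The true size of the step stays unknown, since compound 2 stands at a limit: the limit of > 400000 nM in this assay, at which 2 of the 4 values shown sit.

On these data alone, whether nitro is special here stays open, as an amine or a nitrile at the same place would show. One pair also cannot say whether nitro acts the same way on the other cores.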